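This account rests on a few compounds, and the source may have more. Where it says the series, first, only, none or still open, it means among the compounds named here.

Compound 1 `CC(C)(CO)CNC(=O)c1cc2cc(C#N)ccc2n1Cc1cccc(OC(F)(F)F)c1`, compound 2 `CC(O)CCNC(=O)c1cc2cc(C#N)ccc2n1Cc1cccc(OC(F)(F)F)c1` and compound 3 `N#Cc1ccc2c(c1)cc(C(=O)NCCC(O)(C(F)(F)F)C(F)(F)F)n2Cc1cccc(OC(F)(F)F)c1` share one core and differ only in the hydroxyl-bearing chain on the amide nitrogen. In an in vitro ADME assay on microsomes from Gut (Homo sapiens) for metabolic stability, in the presence of a further agent that is not named here (on this read-out lower numbers stand for slow clearance and higher numbers for fast clearance), compound 1 gives 136 mL.min-1.g-1. Compound 2 gives < 6 mL.min-1.g-1, which is a limit of the assay and not a number. Compound 3 gives < 6 mL.min-1.g-1, also a limit. Compound 3 therefore stands at the limit of < 6 mL.min-1.g-1 in this assay, at which 2 of the 3 values shown sit, with its true value unknown.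

Compound 4 `N#Cc1ccc2c(c1)cc(C(=O)NCCC1(O)CCC1)n2Cc1cccc(OC(F)(F)F)c1` comes from compound 3 through a single change: 1-hydroxycyclobutyl in place of 2,2,2-trifluoro-1-hydroxy-1-(trifluoromethyl)ethyl on a saturated chain carbon, two bonds along the chain from an amide-type nitrogen. In words, 1-hydroxycyclobutyl replaces 2,2,2-trifluoro-1-hydroxy-1-(trifluoromethyl)ethyl on a saturated chain carbon, two bonds along the chain from an amide-type nitrogen.

Two measured steps are large and beyond the scatter: an at least 22-fold lower number from compound 1 to compound 2 (1.35 log units; beyond the scatter) and an at least 22-fold lower number from compound 1 to compound 3 (1.35 log units; beyond the scatter). Both lead away from the chain of compound 1, and compound 4 does not carry that chain. The step most like the new one is a step that the two limits leave unreadable from compound 2 to compound 3, but it swaps a group at the same place and gives no size. Compound 4 has no measured close match, so a modest rise is expected rather than a large one, and a result at the limit remains possible. The estimated change is an at least 1.6-fold higher number from compound 3 to compound 4 (0.22 log units; that floor lies within the scatter). For compound 4 the expected value is 10 mL.min-1.g-1, with an estimated range from 4 mL.min-1.g-1 to 50 mL.min-1.g-1.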

Compound 4, intrinsic clearance in microsomes: < 6 mL.min-1.g-1
Compound 4: only a limit was reported (the forecaster's own chance of this, stated with the estimate: 50%); middle value at least 1.6-fold (0.22 log units) away from the limit.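

In this assay compound 4 gives < 6 mL.min-1.g-1, which is a limit of the assay and not a number. Set against the chain of compound 1, the change gives an at least 22-fold lower number from compound 1 to compound 4 (1.35 log units; beyond the scatter), so a 1-hydroxycyclobutyl group, with its four-membered ring of carbon only and no fluorine, lands in the same low range as the open-chain groups of compound 2 and compound 3, and among the four compounds shown only compound 1 stands apart. The steps among compound 2, compound 3 and compound 4 cannot be read, so this position tolerates all three groups without any order among them being visible: the limit of < 6 mL.min-1.g-1 in this assay, at which 3 of the 4 values shown sit.

From the compounds shown here alone, how far each of these three compounds lies under the limit stays unknown, and so does any ranking among them, which would need a test able to read lower clearance values. Also open, going by these compounds, is whether the low values hold when an amine or a methoxy group takes the place of the hydroxyl, or when a longer chain carries the hydroxyl further from the amide nitrogen.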